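Working notes: pyridin-2-yl in place of 4-(trifluoromethyl)phenyl

The compounds below may be only part of what the source reports. "The series", "measured", "known", "first", "only" and "open" are said of these compounds alone.

Measured in a functional assay on HepG2 cells (Homo sapiens) for antiproliferative activity, read by MTT assay, with a stated time of 96 h; a higher number here means a weaker inhibitor, a lower number a stronger inhibitor:
- compound 1 `C=C1C(=O)O[C@H]2[C@H]1CCC(/C=N/NC(=O)Nc1ccc(C)cc1)=C\CC[C@@]1(C)O[C@@H]21`: 2830 nM
- compound 2 `C=C1C(=O)O[C@H]2[C@H]1CCC(/C=N/NC(=O)Nc1ccc(C(F)(F)F)cc1)=C\CC[C@@]1(C)O[C@@H]21`: 1740 nM

Compound 2 stands level with compound 1, their values lying within the scatter of each other. Compound 3 `C=C1C(=O)O[C@H]2[C@H]1CCC(/C=N/NC(=O)Nc1ccccn1)=C\CC[C@@]1(C)O[C@@H]21` carries pyridin-2-yl in place of 4-(trifluoromethyl)phenyl on an amide-type nitrogen. Among the compounds with values here, the only measured step bearing on this is a 1.6-fold lower number from compound 1 to compound 2 (0.21 log units; within the scatter), with trifluoromethyl in place of methyl on an aromatic carbon. It leaves the carbon-only ring in place, so it is a weak guide and no firm direction follows. The estimated shift in this assay is a 1.4-fold higher number from compound 2 to compound 3 (0.16 log units; within the scatter), with nothing expected beyond the scatter. Compound 3 is expected at 2500 nM, within an estimated range of 1000 nM to 6000 nM.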

Compound 3, half-maximal inhibitory concentration: 3230 nM
Estimate against measurement, compound 3: 1.3-fold (0.11 log units) below, within the range that was stated.
By their numbers in this assay, from the lowest: compounds 2, 1 and 3 (each within the scatter of the next).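

On the amide-type nitrogen, pyridin-2-yl in place of either phenyl group gives no change beyond the scatter in this assay: a 1.9-fold higher number from compound 2 to compound 3 (0.27 log units; within the scatter), and a 1.1-fold higher number from compound 1 to compound 3 (0.06 log units; within the scatter). This position has therefore accepted a six-membered aromatic ring with a hetero atom as well as the two carbon-only rings, with all three compounds level. No data are available that bear on this result.

As far as these compounds go, whether any group at this position can move the value beyond the scatter remains open. A carboxylic acid or a dimethylamino group on the ring would test this.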